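The source may report more compounds than this note shows. Statements on the series, on what has been measured and on what is new or still open speak of the compounds shown alone.

Measured compounds:
Compound 1, `N#C[C@@H]1CCCN1C(=O)[C@@H]1C[C@H](C(=O)N2CCOCC2)CN1`: 73%
Compound 2, `CCCNC(=O)[C@@H]1CN[C@H](C(=O)N2CCC[C@H]2C#N)C1`: 59%
Compound 3, `N#C[C@@H]1CCCN1C(=O)[C@@H]1C[C@H](C(=O)N2CCCCCC2)CN1`: 68%

All three share a core and differ only in the amine on the carbonyl carbon. In an assay on the whole organism (plasma, strain Sprague-Dawley) for inhibition of Dipeptidyl peptidase 4 (Rattus norvegicus), with a stated time of 6 h, at a dose of 1 mg/kg by the oral route (a lower number here means less inhibition, a higher number more inhibition at the dose given (going by the name of the read-out)), compound 3 sits second highest of the three numbers, but both of its gaps are within the scatter: a number 5 percentage points lower from compound 1 to compound 3 (within the scatter), and a number 9 percentage points higher from compound 2 to compound 3 (within the scatter). Among the measured compounds shown here, the only step beyond the scatter is a number 14 percentage points lower from compound 1 to compound 2 (beyond the scatter), where the acyclic propylamino gave a lower number than the cyclic morpholin-4-yl.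

Compound 4, `CN(C)C(=O)[C@@H]1CN[C@H](C(=O)N2CCC[C@H]2C#N)C1`, has not yet been measured in this assay. It differs from compound 3 in one place: dimethylamino in place of azepan-1-yl on a carbonyl carbon. For the measured compounds named here, the steps that bear on this are the two that exchange the azepan-1-yl against another amine on the same carbon, both within the scatter, together with the one step that replaced a cyclic amine by an acyclic one, which was modest and downward. On that basis compound 4 is expected to give a number close to that of compound 3, with a slight lean downward, so that the expected step of a number 5 percentage points lower from compound 3 to compound 4 (within the scatter) remains within the scatter. The estimate for compound 4 in this assay is 63%, in a range from 50% to 76%.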

Compound 4, a percentage reported as inhibition, in the whole organism at one dose (the size of the read-out at that dose, not a potency): 76%
Compound 4: the middle estimate sits 13 percentage points below what was measured, and the stated range covers the measured number.
By their numbers in this assay, from the lowest: compounds 2, 3, 1 and 4 (each within the scatter of the next, the first and the last beyond it).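

In this assay, dimethylamino on this carbonyl carbon reads level with both ring amines: a number 8 percentage points higher from compound 3 to compound 4 (within the scatter) and a number 3 percentage points higher from compound 1 to compound 4 (within the scatter). An open-chain amine here therefore does not in itself go with a lower number, as the earlier step from morpholin-4-yl to propylamino alone might have suggested, since the two open-chain amines themselves differ, with a number 17 percentage points higher from compound 2 to compound 4 (beyond the scatter). Among the compounds shown here, compound 2 is now the only compound of the four that carries the amide hydrogen, and it lies beyond the scatter from compound 1 and compound 4, although compound 3 goes against a clean split, as its step from compound 2 stays within the scatter; nothing at hand explains any of these steps.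

The compounds shown leave open whether the difference between the two open-chain amines follows the amide hydrogen or the length of the chain, which methylamino and butylamino on the same carbon could help to separate. They also leave open how pyrrolidin-1-yl or piperidin-1-yl would read here, and whether ring size has any bearing on the number at this single dose and time.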